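From Nitro to Benzyloxy: One Change Awaiting a Number

This account rests on a few compounds, and the source may have more. Where it says the series, first, only, none or still open, it means among the compounds named here.

Measured so far:
compound 1, `C[C@H](c1ccccc1)n1cnc2c(N(C)C)ncnc21`: 33%
compound 2, `CSc1ncnc2c1ncn2Cc1ccccc1`: 30%
compound 3, `CN(C)c1ncnc2c1ncn2Cc1cccc([N+](=O)[O-])c1`: 17%

All three compounds were tested in a functional assay on the whole organism for inhibition, with Rattus norvegicus as the target, in the maximal electroshock model, at a dose of 25 mg/kg by the intraperitoneal route (on this read-out lower numbers stand for less inhibition and higher numbers for more inhibition at the one dose given (going by the name of the read-out)), a test in which an animal receives one fixed dose and the read-out tells how far seizures are held back. In this assay compound 1 gives 33% and compound 2 gives 30%, two values that sit within the usual scatter of each other. Compound 3 gives 17%, the lowest of the three numbers: its nearest neighbour is compound 2, a number higher by more than the scatter, and the furthest is compound 1, higher still.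

The next compound, compound 4, `CN(C)c1ncnc2c1ncn2Cc1cccc(OCc2ccccc2)c1`, has not yet been tested. Compared with compound 3 the difference is benzyloxy in place of nitro on an aromatic carbon; the shared core and the rest of the molecule stay as they are.

Going by the values given here, no measured pair here shows this particular swap, so the size of its effect can only be guessed. Compound 3 stands apart from the other two, and a return toward their level seems plausible, so a small upward step, a number 8 percentage points higher from compound 3 to compound 4 (within the scatter), is expected, one that may still fall within the scatter. Compound 4 is therefore estimated at 25%, with a range from 10% to 45%.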

Compound 4, a percentage reported as inhibition, in the whole organism at one dose (the size of the read-out at that dose, not a potency): 33%
For compound 4 the middle estimate is 8 percentage points below the measured one, and the stated range covers the measured number.
By their numbers in this assay, from the lowest: compound 3; then compounds 2, 1 and 4 (each within the scatter of the next).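

Going by these compounds alone, replacing nitro with benzyloxy on this aromatic carbon gives a number 16 percentage points higher from compound 3 to compound 4 (beyond the scatter) in this assay, which shows that the read-out responds to what sits at this place, something the earlier compounds could not show, since no two of them differ in one place only. The entering group is the larger by count, with 8 heavy atoms against 3, and it brings a six-membered aromatic ring that nitro lacks, so a group of this size at this place goes with a higher number, not a lower one. No evidence is at hand on which feature of the change lies behind this rise.

On these data alone, a single swap cannot separate losing nitro from gaining benzyloxy, so it remains open whether a small group such as methoxy or an amine on the same carbon would give a number nearer to that of compound 3 or that of compound 4. As far as these compounds go, it also remains open whether a longer chain ending in a phenyl ring, such as phenethoxy, would raise the number further or lower it again.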